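The compounds below may be only part of what the source reports. "The series", "measured", "known", "first", "only" and "open" are said of these compounds alone.

Working notes on the alkoxy series

Three members of the series carry the same core and differ only in the chain on the aromatic oxygen. In a functional assay on A549 cells (Homo sapiens) for cytotoxicity, with a stated time of 48 h (on this read-out lower numbers stand for stronger inhibition and higher numbers for weaker inhibition), compound 1 `CCCCCOc1ccc2oc(/C=C/[S+](C)[O-])cc(=O)c2c1` gives 1600 nM. Compound 2 `CC(C)COc1ccc2oc(/C=C/[S+](C)[O-])cc(=O)c2c1` gives 1100 nM in this assay, and compound 3 `CCCCOc1ccc2oc(/C=C/[S+](C)[O-])cc(=O)c2c1` gives 1400 nM. None of the three is set apart: the step of a 1.5-fold lower number from compound 1 to compound 2 (0.16 log units; within the scatter), the step of a 1.1-fold lower number from compound 1 to compound 3 (0.06 log units; within the scatter) and the step of a 1.3-fold higher number from compound 2 to compound 3 (0.10 log units; within the scatter) all stay inside the scatter, so compound 3 sits with its two neighbours and cannot be ranked against either.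

Compound 4 `CCCOc1ccc2oc(/C=C/[S+](C)[O-])cc(=O)c2c1` takes the chain of compound 3 one carbon shorter: hydrogen in place of methyl on a saturated chain carbon, three bonds along the chain from an oxygen on an aromatic ring. Going by the values given here, the closest precedent is the same kind of trimming one bond further out, a 1.1-fold lower number from compound 1 to compound 3 (0.06 log units; within the scatter), which produced no movement beyond the scatter; the branch-for-chain swaps in a 1.5-fold lower number from compound 1 to compound 2 (0.16 log units; within the scatter) and a 1.3-fold higher number from compound 2 to compound 3 (0.10 log units; within the scatter) were likewise flat. On that basis the step is expected to be no change at the digits printed from compound 3 to compound 4 (within the scatter), with no shift beyond the scatter. Compound 4 is therefore estimated at 1400 nM in this assay, expected to fall between 700 nM and 2800 nM.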

Compound 4, half-maximal inhibitory concentration: 1100 nM
For compound 4 the middle estimate is 1.3-fold (0.10 log units) above the measured one; the measured number falls inside the stated range.
By their numbers in this assay, from the lowest: compounds 2, 4, 3 and 1 (each within the scatter of the next).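

In this assay, butyl to propyl gives a 1.3-fold lower number from compound 3 to compound 4 (0.10 log units; within the scatter), so hydrogen in place of methyl, three bonds along the chain from an oxygen on an aromatic ring, is tolerated here as far as the scatter can tell. The other two steps to the new compound, no change at the digits printed from compound 2 to compound 4 (within the scatter) and a 1.5-fold lower number from compound 1 to compound 4 (0.16 log units; within the scatter), are just as flat, so the flat stretch now covers four chains, with none set apart. The same change also reads alike on two different cores: the same change on two cores in this assay, a 1.1-fold lower number (0.06 log units; within the scatter) from compound 1 to compound 3 and no change at the digits printed (within the scatter) from compound 2 to compound 4, 1.1-fold (0.06 log units) apart, within the scatter of two such steps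

Still open, from the compounds shown here alone, is whether any group on this oxygen moves the number beyond the scatter, for example a methyl or ethyl ether, a longer chain such as octyl, or a chain carrying an amine or a carboxylic acid.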